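This account rests on a few compounds, and the source may have more. Where it says the series, first, only, none or still open, it means among the compounds named here.

Measured compounds:
compound 1 `Nc1ccccc1NC(=O)c1ccc(CSC(=S)N2CCN(c3ccc(Cl)cc3)CC2)cc1`, which in a functional assay on A-375 cells (Homo sapiens) for antiproliferative activity, read by CCK-8 assay, with a stated time of 72 h, tested at 2 uM (on this read-out lower numbers stand for a weaker effect and higher numbers for a stronger effect at the one concentration tested), gives 32.2%;
compound 2 `Nc1ccccc1NC(=O)c1ccc(CSC(=S)N2CCc3ccc([N+](=O)[O-])cc32)cc1`, which gives 22.1%;
compound 3 `Nc1ccccc1NC(=O)c1ccc(CSC(=S)N2CCN(c3ccc(F)cc3)CC2)cc1`, which gives 20.9%.

Compound 3 has the lowest of the three numbers. Its nearest neighbour is compound 2, a gap within the scatter, so no order between these two can be claimed. The furthest value belongs to compound 1. The step of a number 11.3 percentage points lower from compound 1 to compound 3 (beyond the scatter) lies beyond the scatter. Compound 4 `Nc1ccccc1NC(=O)c1ccc(CSC(=S)N2CCN(Cc3cccnc3)CC2)cc1` differs from compound 3 in one place: (pyridin-3-yl)methyl in place of 4-fluorophenyl on an amine nitrogen in a ring. Among the measured compounds shown here, the only measured step touching this part of the molecule is fluoro in place of chloro on an aromatic carbon, a modest step, and it does not tell what replacing the whole group does. A small step at most, in either direction, is therefore expected in this assay. Compound 4 is expected at 22%, with a range from 10% to 38%. The expected step is a number 1.1 percentage points higher from compound 3 to compound 4 (within the scatter).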

Compound 4, a percentage reported as inhibition, at one concentration (the size of the read-out at that concentration, not a potency): 31.5%
Estimate against measurement, compound 4: 9.5 percentage points below; the range from low to high includes it.
By their numbers in this assay, from the lowest: compounds 3, 2, 4 and 1 (each within the scatter of the next, the first and the last beyond it).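

Replacing 4-fluorophenyl with (pyridin-3-yl)methyl on the ring's amine nitrogen gives a number 10.6 percentage points higher from compound 3 to compound 4 (beyond the scatter) in this assay, so exchanging the whole group can change this read-out. Against the 4-chlorophenyl group, the same replacement gives a number 0.7 percentage points lower from compound 1 to compound 4 (within the scatter), so compound 1 and compound 4 cannot be told apart here. Nothing available explains either step.

As far as these compounds go, the change brings in a ring nitrogen and a methyl link together, so the share of each in the step from the 4-fluorophenyl compound remains open. A benzyl group on this amine nitrogen would separate the two.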